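Extending the amine of compound 3 with an oxanylmethyl group

A few compounds are considered here, and "the series" means these few. Any claim that something is new, unique, unknown or untested is made for them only; others in the source may bear on it.

Compound 3 `CC(C)(CN)CCN(C[C@H]1Cc2ccccc2CN1)[C@H]1CCCc2cccnc21` is tested in a functional assay on cells for agonist activity at C-X-C chemokine receptor type 4 (Homo sapiens), read by fluorescence and calcium flux, with a stated time of 90 s (on this read-out higher numbers stand for an effect only at larger amounts of compound and lower numbers for an effect already at smaller amounts), and gives > 30000 nM, which is a limit rather than a number. Compound 1 `c1cncc(CNCCCCN(C[C@H]2Cc3ccccc3CN2)[C@H]2CCCc3cccnc32)c1` in this assay also reaches only a limit, > 30000 nM. Compound 2 `O=S1(=O)CCC(CNCCCCN(C[C@H]2Cc3ccccc3CN2)[C@H]2CCCc3cccnc32)CC1` likewise gives a limit, > 30000 nM. All three share (the limit of > 30000 nM in this assay, at which 3 of the 3 values shown sit), so the steps a step that the two limits leave unreadable from compound 1 to compound 2, a step that the two limits leave unreadable from compound 1 to compound 3 and a step that the two limits leave unreadable from compound 2 to compound 3 cannot be sized. Compound 4 `CC(C)(CCN(C[C@H]1Cc2ccccc2CN1)[C@H]1CCCc2cccnc21)CNCC1CCOCC1` carries (oxan-4-yl)methyl in place of hydrogen on an amine nitrogen, a change at the same chain end as the unreadable ones. With no readable step to lean on, compound 4 is expected to show a number no higher from compound 3 to compound 4 (the limit leaves the size open), none beyond the scatter, and most likely another limit. The expected value for compound 4 is 30000 nM, within 8000 nM to 100000 nM.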

Compound 4, half-maximal effective concentration: > 30000 nM
Compound 4 ended at the assay's limit (the forecaster's own chance of this, stated with the estimate: 80%); the middle value lies on the limit itself.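

Compound 4 adds no readable step to compound 1, compound 2 or compound 3, because all four stop at the same limit: the limit of > 30000 nM in this assay, at which 4 of the 4 values shown sit. The compounds shown leave open whether any of these groups, (oxan-4-yl)methyl included, changes the read-out at all.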